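The source may report more compounds than this note shows. Statements on the series, on what has been measured and on what is new or still open speak of the compounds shown alone.

In a functional assay on cells (Cancer cell lines, Homo sapiens) for cytotoxicity, read by sulforhodamine B assay, with a stated time of 48 h (a higher number here means a weaker inhibitor of growth, a lower number a stronger inhibitor of growth), the three measured compounds stand as follows:

- compound 1 `O=C1N=C(N2N=C(c3ccccc3)CC2c2ccccc2O)S/C1=C1/C(=O)Nc2ccccc21` gives 2090 nM
- compound 2 `O=C1N=C(N2N=C(c3ccccc3)CC2c2ccccc2O)S/C1=C1/C(=O)Nc2ccc(Br)cc21` gives 260 nM
- compound 3 `COc1ccc(C2CC(c3ccc4ccccc4c3)=NN2C2=NC(=O)/C(=C3\C(=O)Nc4ccc(Br)cc43)S2)cc1` gives 61 nM

Compound 1 has the highest number of the three, so it is the weakest growth inhibitor among them; compound 2 is nearest to it, and compound 3 is furthest away. The only single-point step among these compounds is an 8.0-fold lower number from compound 1 to compound 2 (0.91 log units; beyond the scatter), a bromo on the ring of the shared core. Compound 4 `CN(C)c1ccc(C2CC(c3ccccc3)=NN2C2=NC(=O)/C(=C3\C(=O)Nc4ccccc43)S2)cc1` differs from compound 1 in another place altogether: 4-(dimethylamino)phenyl in place of 2-hydroxyphenyl on a saturated ring carbon. Going by the values given here, no measured pair shows this change, so nothing among the numbers tells how large a step it brings or in which direction. The expectation for compound 4 therefore rests on the value of compound 1 alone, with a wide range to cover the lack of a guiding step. Compound 4 is expected to give 1500 nM in this assay, between 400 nM and 6000 nM, which means an estimated step of a 1.4-fold lower number from compound 1 to compound 4 (0.14 log units; within the scatter).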

Compound 4, concentration for 50% growth inhibition: 5260 nM
Compound 4: middle estimate off by 3.5-fold (0.54 log units), on the low side; measured number inside the range.
By their numbers in this assay, from the lowest: compound 3; then compound 2; then compound 1; then compound 4.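

In this assay the saturated ring carbon now has a measured step of its own: 4-(dimethylamino)phenyl in place of 2-hydroxyphenyl gives a 2.5-fold higher number from compound 1 to compound 4 (0.40 log units; beyond the scatter), so the group on this carbon does affect the reading. The change goes toward weaker growth inhibition, unlike the bromo step, which went toward stronger inhibition at a different place on the shared core. Nothing measured here explains why this swap, which leaves 0 hydrogen-bond donors where there was 1 and enlarges the group, has this effect.

Going by these compounds, the swap removes the hydroxy group and adds the dimethylamino group in one move, so the share of each stays open; a plain phenyl group on this carbon would separate the two. On these data alone, whether the step holds with a bromo on the core is also open.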